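The compounds below may be only part of what the source reports. "The series", "measured", "known", "first", "only" and "open" are said of these compounds alone.

Three measured compounds share one core. Compound 1 `C[C@H](NC(=O)c1nnn(Cc2ccc(F)cc2)c1C(F)(F)F)c1ccc(C(=O)O)cc1` gives > 10000 nM in a functional assay on CHO cells for antagonist activity at prostaglandin E2 receptor EP4 subtype (Homo sapiens), read by calcium flux, with a stated time of 15 min (a lower number here means a stronger inhibitor, a higher number a weaker inhibitor), and this value is a limit of the assay rather than a number. Compound 2 `C[C@H](NC(=O)c1nnn(Cc2ccc(C(F)(F)F)cc2)c1C(F)(F)F)c1ccc(C(=O)O)cc1` gives > 10000 nM in this assay, also only a limit. Compound 3 `C[C@H](NC(=O)c1nnn(CCOc2ccc(F)cc2)c1C(F)(F)F)c1ccc(C(=O)O)cc1` gives > 10000 nM in this assay, again a limit. Because (the limit of > 10000 nM in this assay, at which 3 of the 3 values shown sit), the steps a step that the two limits leave unreadable from compound 1 to compound 2, a step that the two limits leave unreadable from compound 1 to compound 3 and a step that the two limits leave unreadable from compound 2 to compound 3 cannot be given a size, and none of them touches the position changed next. Compound 4 `C[C@H](NC(=O)c1cn(Cc2ccc(C(F)(F)F)cc2)nn1)c1ccc(C(=O)O)cc1` differs from compound 2 by hydrogen in place of trifluoromethyl on an aromatic carbon. The expected step that the limit leaves unreadable from compound 2 to compound 4 is thus unsupported by any readable step, and a limit is again the likeliest outcome. Compound 4 is estimated at 15000 nM, in a range from 3000 nM to 60000 nM.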

Compound 4, half-maximal inhibitory concentration: > 10000 nM
Compound 4: no number, only a limit (the forecaster's own chance of this, stated with the estimate: 70%); the middle value lies beyond the limit too.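

The step from compound 2 to compound 4 cannot be read, since each gives only a limit of the assay: the limit of > 10000 nM in this assay, at which 4 of the 4 values shown sit. The compounds shown leave open what effect, if any, swapping trifluoromethyl for hydrogen has on inhibition in this assay.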